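The compounds below may be only part of what the source reports. "The series", "measured", "known", "first", "only" and "open" are said of these compounds alone.

Working notes on the series in an ADME assay on BJ cells (Homo sapiens) for cytotoxicity, read by MTT assay, with a stated time of 72 h; on this read-out higher numbers stand for weaker inhibition and lower numbers for stronger inhibition. Compound 1 (`COc1cc(CNc2ncnc3c2ncn3C2CCCCO2)ccc1O`) reads > 100000 nM, a limit of the assay. Compound 2 (`COc1cccc(CNc2ncnc3c2ncn3C2CCCO2)c1`) reads > 100000 nM, also a limit. Compound 3 (`COc1ccc(CNc2ncnc3c2ncn3C2CCCO2)cc1OC`) reads > 100000 nM, again only a limit, so it has no numerical position in the series. The three compounds share one ceiling: the limit of > 100000 nM in this assay, at which 3 of the 3 values shown sit. Compound 4 (`COc1cc(CNc2ncnc3c2ncn3C2CCCO2)ccc1O`) comes from compound 3 by hydrogen in place of methyl on an oxygen on an aromatic ring, that is, methoxy to hydroxy. Going by the values given here, the one measured step on this ring is a step that the two limits leave unreadable from compound 2 to compound 3, and it gives no size to carry over. No step beyond the scatter is therefore expected in this assay, and no direction can be assigned. The expected step is a step that the limit leaves unreadable from compound 3 to compound 4. Compound 4 is estimated at 120000 nM, with an expected range of 50000 nM to 250000 nM.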

Compound 4, half-maximal inhibitory concentration: > 100000 nM
Compound 4 gave a limit, no number; the forecaster's own chance of this, stated with the estimate: 85%; the middle value is on the limit's open side.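

In this assay no step can be read between compound 4 and compound 1, compound 2 or compound 3, as all four rest on one ceiling: the limit of > 100000 nM in this assay, at which 4 of the 4 values shown sit. The compounds shown leave open whether any of these changes shifts the read-out, since none has a numerical position.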